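Ethyl to Isopropylcarbonyl on the Ring Nitrogen of Compound 3

This account rests on a few compounds, and the source may have more. Where it says the series, first, only, none or still open, it means among the compounds named here.

Measured compounds:
compound 1 `CCCCCCNC(=O)n1cc(CC)c(=O)[nH]c1=O` gives 733 nM in an assay on HEK293 cells for inhibition of acid ceramidase (Rattus norvegicus), read by LC-MS, with a stated time of 30 min; on this read-out lower numbers stand for stronger inhibition and higher numbers for weaker inhibition;
compound 2 `CCCCCCNC(=O)n1cc(C#N)c(=O)[nH]c1=O` gives no result reported in this assay;
compound 3 `CCCCCCNC(=O)n1cc(F)c(=O)n(CC)c1=O` gives 18 nM in this assay.

Among the two numbers at hand, compound 3 stands at the lowest; the nearest is compound 1, whose number is higher by a margin that lies well beyond the scatter. Compound 2 contributes no number and so cannot be placed.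

Compound 4 `CCCCCCNC(=O)n1cc(F)c(=O)n(C(=O)C(C)C)c1=O` is the untested variant. It differs from compound 3 in one place: isopropylcarbonyl in place of ethyl on an aromatic nitrogen. The change sits on an aromatic nitrogen of a six-membered aromatic ring with two nitrogens, ortho to two groups of one heavy atom each, meta to a fluoro group and meta to a group of nine heavy atoms.

Going by the values given here, no pair of measured compounds shows this particular change, so there is no measured step to lean on. The expectation is for a modest step in this assay, more likely toward a higher number than a lower one, but one that may not exceed the scatter. Compound 4 is therefore estimated at 40 nM, with a range from 8 nM to 200 nM. The step from compound 3 to compound 4 that this estimate implies is a 2.2-fold higher number from compound 3 to compound 4 (0.35 log units; beyond the scatter).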

Compound 4, half-maximal inhibitory concentration: 21 nM
For compound 4 the middle estimate is 1.9-fold (0.28 log units) above the measured one; the range from low to high includes it.
By their numbers in this assay, from the lowest: compounds 3 and 4 (each within the scatter of the next); then compound 1.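

The exchange of ethyl for isopropylcarbonyl on an aromatic nitrogen gives a 1.2-fold higher number from compound 3 to compound 4 (0.07 log units; within the scatter) in this assay and so leaves compound 3 and compound 4 indistinguishable on this read-out. Going by these compounds alone, this is the first measured step at this position, and it shows that a group of 5 heavy atoms, carrying a carbonyl and a hydrogen-bond acceptor, can stand in place of ethyl with its 2 heavy atoms and no acceptor, without moving the number beyond the usual scatter. Nothing measured here explains why the number stays flat across this change.

As far as these compounds go, how far this flat behaviour extends remains open: a longer chain, an amine or a carboxylic acid on the same aromatic nitrogen might keep the number in this range or might move it well away. Also open, from the compounds shown here alone, is what a plain hydrogen on that nitrogen would give with the fluoro group kept in place, and so how much either ethyl or isopropylcarbonyl contributes to the values of compound 3 and compound 4.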